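A few compounds are considered here, and "the series" means these few. Any claim that something is new, unique, unknown or untested is made for them only; others in the source may bear on it.

Working notes on the series.

Compound 1 `COc1cc(-c2ccnc3cc(-c4ccc(C(C)(C)C)cc4)nn23)cc(OC)c1OC` carries a 4-(tert-butyl)phenyl on the shared core. In a functional assay on MCF7 cells (Homo sapiens) for inhibition, read by CCK-8 assay, with a stated time of 48 h (a lower number here means a stronger inhibitor, a higher number a weaker inhibitor), compound 1 gives only a limit, > 10000 nM, not a number. This is the point (the limit of > 10000 nM in this assay, at which 1 of the 2 values shown sits), so where compound 1 stands on the scale is open beyond that limit.

Compound 2 `COc1cc(-c2ccnc3cc(-c4cn(C)c5ccccc45)nn23)cc(OC)c1OC` differs from compound 1 in one place, 1-methyl-1H-indol-3-yl in place of 4-(tert-butyl)phenyl on an aromatic carbon. In this assay compound 2 gives 95 nM, and the step of an at least 100-fold lower number from compound 1 to compound 2 (2.02 log units; beyond the scatter) is large.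

Compound 3 `COc1cc(-c2ccnc3cc(-c4ccc(C(F)(F)F)cc4)nn23)cc(OC)c1OC` is not yet measured. It differs from compound 1 by trifluoromethyl in place of tert-butyl on an aromatic carbon, the phenyl itself staying in place. For the measured compounds named here, the one measured step swaps the whole aryl group and so bears only loosely on this smaller change; no measured pair separates tert-butyl from trifluoromethyl on that ring. Compound 3 is therefore expected to stay near where compound 1 sits, with a modest step of an at least 1.2-fold lower number from compound 1 to compound 3 (0.09 log units; that floor lies within the scatter) that may well fall within the scatter. The estimate for compound 3 in this assay is 8000 nM, ranging from 2000 nM to 30000 nM.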

Compound 3, half-maximal inhibitory concentration: 2440 nM
Compound 3: middle estimate off by 3.3-fold (0.52 log units), on the high side; low and high end bracket the measured number.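

Swapping only the substituent on the phenyl, with the ring itself unchanged, is enough to move the read-out in this assay: the step is an at least 4.0-fold lower number from compound 1 to compound 3 (0.61 log units; beyond the scatter). A 4-substituted phenyl at this position is therefore not uniformly inactive, and the choice between tert-butyl and trifluoromethyl matters, which the whole-aryl swap could not show. Even so, 4-(trifluoromethyl)phenyl does not match the indole group, as the step of a 26-fold higher number from compound 2 to compound 3 (1.41 log units; beyond the scatter) shows, and the size of the step out of compound 1 remains a floor, since compound 1 gives only a limit and not a number: the limit of > 10000 nM in this assay, at which 1 of the 3 values shown sits.

Going by these compounds, what a nitrile, an amine or a carboxylic acid would give in place of trifluoromethyl on the phenyl remains open, so a single pair of substituents cannot yet be read as a trend. Also open, on these data alone, is how the indol-3-yl group would read without its methyl, or with a longer chain in its place.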